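Hydroxy in Place of Amino on a Shared Core

The compounds below may be only part of what the source reports. "The series", "measured", "known", "first", "only" and "open" are said of these compounds alone.

In a functional assay on SH-SY5Y cells (Homo sapiens) for cytotoxicity, read by MTT assay (a higher number here means a weaker inhibitor, a lower number a stronger inhibitor), compound 1 (`COc1ccc(-c2cocc2-c2cc(OC)c(OC)c(OC)c2)cc1`) gives 39 nM. Among the measured compounds shown here, compound 2 (`COc1ccc(-c2cocc2-c2cc(OC)c(OC)c(OC)c2)cc1N`) gives 5.1 nM, the lower of the two numbers measured so far. For the measured compounds named here, the one measured step is a 7.6-fold lower number from compound 1 to compound 2 (0.88 log units; beyond the scatter). It lies beyond the scatter and is modest in size, and it comes with amino in place of hydrogen on an aromatic carbon.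

Compound 3 (`COc1ccc(-c2cocc2-c2cc(OC)c(OC)c(OC)c2)cc1O`) has not been measured. It differs from compound 2 at that same spot, ortho to a methoxy group: hydroxy in place of amino on an aromatic carbon. This is hydroxy in place of amino on an aromatic carbon.

Going by the values given here, no measurement yet shows what hydroxy does here, so the evidence is thin. The step of a 7.6-fold lower number from compound 1 to compound 2 (0.88 log units; beyond the scatter) shows only what happens when hydrogen gives way to amino. Compound 3 still carries a group other than hydrogen at that spot, so most of that drop may well survive, though some could be lost. An estimated step of a 1.4-fold higher number from compound 2 to compound 3 (0.14 log units; within the scatter) is expected, which stays within the scatter. For compound 3 the expected value in this assay is 7 nM, with an estimated range from 2 nM to 25 nM.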

Compound 3, half-maximal inhibitory concentration: 2.9 nM
For compound 3 the middle estimate is 2.4-fold (0.38 log units) above the measured one; measured number inside the range.
By their numbers in this assay, from the lowest: compounds 3 and 2 (each within the scatter of the next); then compound 1.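

At this position hydroxy and amino cannot be told apart in this assay, since the exchange gives a 1.8-fold lower number from compound 2 to compound 3 (0.25 log units; within the scatter) and so stays inside the normal spread of repeat measurements. Set against the unsubstituted compound, the hydroxy group gives a 13-fold lower number from compound 1 to compound 3 (1.13 log units; beyond the scatter) and so lines up with the earlier amino step. Among these three compounds, the lower number does not depend on amino alone. A second group at the same spot also gives it, and none of the three goes against this reading. The two groups are alike in their computed counts of heavy atoms, hydrogen-bond donors and hydrogen-bond acceptors, but nothing available explains why replacing hydrogen here lowers the number.

The compounds shown leave open whether a group with a different make-up, such as a methyl group, a fluorine atom or a carboxylic acid, would keep the lower number at this spot. They also leave open whether the same ranking would hold for another cell line or read-out, as all three values come from a single test.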